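Cyclic amine at the chain end of the shared core

A few compounds are considered here, and "the series" means these few. Any claim that something is new, unique, unknown or untested is made for them only; others in the source may bear on it.

The series carries one core with varied side chains on the aromatic nitrogen. Compound 1 `CN(C)CCCCCn1c2c(c3ccccc31)C(=O)c1c[n+]([O-])c3ccccc3c1C2=O` gives 470 nM in a functional assay on HCT-116 cells (Homo sapiens) for cytotoxicity, read by MTT assay, with a stated time of 72 h; on this read-out higher numbers stand for weaker inhibition and lower numbers for stronger inhibition. Compound 3 `O=C1c2c[n+]([O-])c3ccccc3c2C(=O)c2c1c1ccccc1n2CCN1CCCC1` gives 270 nM and compound 2 `O=C1c2c[n+]([O-])c3ccccc3c2C(=O)c2c1c1ccccc1n2Cc1cn(CC(O)CO)nn1` gives 250 nM; the steps of a 1.7-fold lower number from compound 1 to compound 3 (0.24 log units; within the scatter) and a 1.9-fold lower number from compound 1 to compound 2 (0.27 log units; within the scatter) both lie within the scatter, as does a 1.1-fold higher number from compound 2 to compound 3 (0.03 log units; within the scatter), so the three measured compounds cannot be told apart on this read-out and compound 1 is not set off from either of the others.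

Compound 4 `CN1CCN(CCCCCCn2c3c(c4ccccc42)C(=O)c2c[n+]([O-])c4ccccc4c2C3=O)CC1` differs from compound 1 as follows: (4-methylpiperazin-1-yl)methyl in place of dimethylamino on a saturated chain carbon, five bonds along the chain from an aromatic nitrogen

The closest measured precedent is the step in which a cyclic amine replaces a dimethylamino-bearing chain, a 1.7-fold lower number from compound 1 to compound 3 (0.24 log units; within the scatter), which stayed within the scatter. The larger change of the whole side chain, a 1.9-fold lower number from compound 1 to compound 2 (0.27 log units; within the scatter), also stayed within the scatter. Within the data shown here, nothing among the measured steps points to a shift beyond the scatter on exchanging one basic terminal group for another, so for compound 4 no step beyond the scatter is expected in this assay; the expected step is a 1.2-fold lower number from compound 1 to compound 4 (0.07 log units; within the scatter). Compound 4 is therefore estimated at 400 nM, with a range from 150 nM to 1000 nM.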

Compound 4, half-maximal inhibitory concentration: 2900 nM
Compound 4: the middle estimate sits 7.3-fold (0.86 log units) below what was measured, outside the stated range (above it).
By their numbers in this assay, from the lowest: compounds 2, 3 and 1 (each within the scatter of the next); then compound 4.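

In this assay, the side chain on the aromatic nitrogen proves less forgiving than compounds 1, 2 and 3 suggested: a 6.2-fold higher number from compound 1 to compound 4 (0.79 log units; beyond the scatter) is a step beyond the scatter, whereas all steps among those three stayed within it. The steps of an 11-fold higher number from compound 3 to compound 4 (1.03 log units; beyond the scatter) and a 12-fold higher number from compound 2 to compound 4 (1.06 log units; beyond the scatter) are larger still, so compound 4 stands apart from all three, with weaker inhibition, even though their side chains range from a short pyrrolidin-1-yl ethyl chain to a triazole bearing a diol. No measurement shown here bears on the reason for this loss.

The change from compound 1 to compound 4 brings in the 4-methylpiperazin-1-yl ring and lengthens the chain at once, so the shift cannot be assigned to either alone; a 6-(dimethylamino)hexyl chain and a 5-(4-methylpiperazin-1-yl)pentyl chain on the aromatic nitrogen would separate the two. Also open, as far as these compounds go, is whether another six-membered ring at the chain end, such as morpholin-4-yl or piperidin-1-yl, would follow compound 4 or stay with compound 1.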